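Cyclohexyl Urea Replaces Phenyl Urea on a Pyridinone Core

This account rests on a few compounds, and the source may have more. Where it says the series, first, only, none or still open, it means among the compounds named here.

Of the compounds shown here, two sharing one core have been measured in a functional assay on the whole organism (artery) for inhibition, with Rattus norvegicus as the target, at a dose of 3 mg/kg by the intraduodenal route; a lower number here means less inhibition, a higher number more inhibition at the dose given (going by the name of the read-out). Compound 1 `CCCCc1ccc(CNC(=O)N(C)C)c(=O)n1Cc1ccc(-c2ccccc2-c2nn[nH]n2)cc1` carries a dimethylamino group on the urea carbonyl and in this assay gives 28%. Within the data shown here, compound 2 `CCCCc1ccc(CNC(=O)Nc2ccccc2)c(=O)n1Cc1ccc(-c2ccccc2-c2nn[nH]n2)cc1` carries an anilino group there and in this assay gives 0%, the lowest of the two numbers; the only step available, a number 28 percentage points lower from compound 1 to compound 2 (beyond the scatter), is beyond the scatter and shows that the anilino urea loses inhibition compared with the dimethylamino urea.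

Compound 3 `CCCCc1ccc(CNC(=O)NC2CCCCC2)c(=O)n1Cc1ccc(-c2ccccc2-c2nn[nH]n2)cc1` is the next compound to be tested in this assay. It differs from compound 2 in one place: cyclohexyl in place of phenyl on an amide-type nitrogen. Among the measured compounds shown here, no measured step changes a phenyl into a cyclohexyl on this nitrogen, so the one step that bears on it is only indirect: it tells that the anilino urea of compound 2 lies at zero, from which the read-out can only stay put or rise. A small gain is therefore expected for compound 3, a number 10 percentage points higher from compound 2 to compound 3 (within the scatter), though a result within the scatter of compound 2 would not surprise. Compound 3 is estimated at 10%, within 0% to 30%.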

Compound 3, a percentage reported as inhibition, in the whole organism at one dose (the size of the read-out at that dose, not a potency): 0%
For compound 3 the middle estimate is 10 percentage points above the measured one, within the range that was stated.
By their numbers in this assay, from the lowest: compounds 2 and 3 (each within the scatter of the next); then compound 1.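

In this assay, cyclohexyl in place of phenyl on the amide-type nitrogen gives no change at the digits printed from compound 2 to compound 3 (within the scatter), so at this dose the read-out does not separate the aromatic ring from the non-aromatic ring of the same size. The comparison with the dimethylamino urea gives a number 28 percentage points lower from compound 1 to compound 3 (beyond the scatter), the same size as a number 28 percentage points lower from compound 1 to compound 2 (beyond the scatter), which shows that the earlier loss is not confined to the anilino urea and also appears with cyclohexylamino on the carbonyl carbon. With compound 2 at 0% and compound 3 at 0%, however, this single-dose read-out cannot show any difference between the two ureas that it does not register at this dose. The data offer no measured explanation for this outcome.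

Still open, from the compounds shown here alone, is whether a urea with a smaller group on this nitrogen, such as methylamino, would stand nearer to compound 1 at 28%. Also open, going by these compounds, is whether a cyclohexyl ring carrying a carboxylic acid or an amine would restore any of the inhibition seen with the dimethylamino urea.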